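Weak inhibitors: a bromophenyl change at the triazole nitrogen

The compounds below may be only part of what the source reports. "The series", "measured", "known", "first", "only" and "open" are said of these compounds alone.

Compound 1 `CC(C)n1ncc2c(C(=O)Nc3ccccc3)cccc21` gives 23700 nM in a functional assay on HepG2 cells (Homo sapiens) for inhibition, read by MTT assay, with a stated time of 72 h; a higher number here means a weaker inhibitor, a lower number a stronger inhibitor.
Compound 2 `Cc1ccc(-n2cc(CNC(=O)c3cccc4c3cnn4C(C)C)nn2)cc1C` gives > 40000 nM in this assay; this is a limit of the assay, not a number.
Compound 3 `Cc1ccc(-n2cc(CNC(=O)c3cccc4c3cnn4C(C)C)nn2)c(C)c1` gives > 40000 nM in this assay; this too is a limit of the assay, not a number.

Compound 3 therefore stands only at a limit: its inhibition was too weak for this assay to return a number, and the same holds for compound 2, so the step that the two limits leave unreadable from compound 2 to compound 3 cannot be read. Within the data shown here, of the three values, the only number belongs to compound 1, whose structure differs from the other two in more than one place, so no single step connects it to them.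

Compound 4 `CC(C)n1ncc2c(C(=O)NCc3cn(-c4cccc(Br)c4)nn3)cccc21` differs from compound 3 by 3-bromophenyl in place of 2,4-dimethylphenyl on an aromatic nitrogen. Among the measured compounds shown here, the only measured step at the same position, a step that the two limits leave unreadable from compound 2 to compound 3, is unreadable, and the limit of > 40000 nM in this assay, at which 2 of the 3 values shown sit, shows how the values cluster there. Nothing measured points to a gain that would bring compound 4 well inside the range of this assay. The expectation is therefore that compound 4 sits at or near the limit again, with the step of a number no higher from compound 3 to compound 4 (the limit leaves the size open) expected to be none beyond the scatter. The estimate for compound 4 is 40000 nM, within 15000 nM to 100000 nM, with a fair chance that only a limit is reported.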

Compound 4, half-maximal inhibitory concentration: > 40000 nM
Compound 4: a limit, no number; the forecaster's own chance of this, stated with the estimate: 60%; the middle value sits exactly at the limit.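

Compound 2, compound 3 and compound 4 each give only a limit and no number in this assay, so none of the steps among these three compounds can be read: the limit of > 40000 nM in this assay, at which 3 of the 4 values shown sit.

The compounds shown leave open how far the 3-bromophenyl, 2,4-dimethylphenyl and 3,4-dimethylphenyl groups on the aromatic nitrogen differ from one another in this assay.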